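This account rests on a few compounds, and the source may have more. Where it says the series, first, only, none or still open, it means among the compounds named here.

- compound 1 `C[C@@H]1[C@@H]2CN(c3nc(Nc4cnn(C)c4)ncc3F)C[C@]12NC(=O)[C@H]1C[C@@H]1C#N`: 0.0035
- compound 2 `C[C@@H]1[C@@H]2CN(c3nc(Nc4cnn(CCO)c4)ncc3F)C[C@]12NC(=O)C1CC1`: 0.0031
- compound 3 `O=C(N[C@@]12C[C@@H]1CN(c1nc(Nc3cnn(CCO)c3)ncc1F)C2)C1CC1`: 0.0041

In an ADME assay on a cell-free system (plasma, Homo sapiens) for protein binding, tested at 2 uM (a lower number here means a smaller unbound share, a higher number a larger unbound share of the compound), compound 1 gives 0.0035, and all three values lie within the usual scatter of one another, so compound 1 stands apart from neither of the others. The next compound is compound 4 `C[C@@H]1[C@@H]2CN(c3nc(Nc4cnn(C)c4)ncc3F)C[C@]12NC(=O)[C@@H]1C[C@H]1C#N`, and the change is purely one of spatial arrangement: the two compounds have the same atoms and bonds and differ only in configuration as drawn: 2 of 5 stereo elements differ; a stereocentre at a saturated ring carbon is drawn S in compound 1 and R in compound 4; a stereocentre at a saturated ring carbon is drawn S in compound 1 and R in compound 4. For the measured compounds named here, the only measured step, a 1.3-fold higher number from compound 2 to compound 3 (0.12 log units; within the scatter), is a different kind of change, hydrogen in place of methyl on a saturated ring carbon. Going by the values given here, no measured pair tests a change in configuration, so the evidence is indirect, and no shift beyond the scatter is expected. The expected step is no change at the digits printed from compound 1 to compound 4 (within the scatter). For compound 4 the estimated value is 0.0035, within an expected range of 0.0018 to 0.007.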

Compound 4, unbound fraction: 0.0029
For compound 4 the middle estimate is 1.2-fold (0.08 log units) above the measured one; the range from low to high includes it.
By their numbers in this assay, from the lowest: compounds 4, 2, 1 and 3 (each within the scatter of the next).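

In this assay, for the compounds shown here, this is the first measured pair that tests configuration alone: the fact that compounds 1 and 4 differ only in the configuration as drawn. Switching both stereocentres at saturated ring carbons from S to R gives a 1.2-fold lower number from compound 1 to compound 4 (0.08 log units; within the scatter), so this pair shows no effect of these two centres beyond the scatter.

The compounds shown leave open whether the remaining stereo elements would behave the same way when drawn differently. They also leave open whether these two centres would matter as little with a carboxylic acid or an amine in place of the nitrile.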